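Replacing the decyl chain of compound 1

A few compounds are considered here, and "the series" means these few. Any claim that something is new, unique, unknown or untested is made for them only; others in the source may bear on it.

In a functional assay on HL-60 cells (Homo sapiens) for cytotoxicity, read by MTT assay, with a stated time of 24 h (on this read-out lower numbers stand for stronger inhibition and higher numbers for weaker inhibition), compound 1 (`CCCCCCCCCCn1cc(Cn2nc(N)c3c(C(F)(F)F)cc(-c4ccccc4)nc32)nn1`) gives 29.9 ug/mL and compound 2 (`Nc1nn(Cc2cn(-c3ccc(F)c(Cl)c3)nn2)c2nc(-c3ccccc3)cc(C(F)(F)F)c12`) gives 35 ug/mL so the two lie within the scatter of each other. Compound 3 (`Nc1nn(Cc2cn(CC(=O)Nc3c(F)cccc3F)nn2)c2nc(-c3ccccc3)cc(C(F)(F)F)c12`) carries (2,6-difluorophenyl)carbamoyl in place of nonyl on a saturated chain carbon bound to an aromatic nitrogen. Among the measured compounds shown here, only one measured step bears on this: compound 2 also loses the decyl chain of compound 1 (a 1.2-fold higher number from compound 1 to compound 2 (0.07 log units; within the scatter)). No step beyond the scatter is therefore expected in this assay (a 1.1-fold higher number from compound 1 to compound 3 (0.03 log units; within the scatter)). For compound 3 the estimate is 32 ug/mL with an expected range from 14 ug/mL to 70 ug/mL on this read-out.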

Compound 3, half-maximal inhibitory concentration: 32.8 ug/mL
Beside the measured number, compound 3's estimate is 1.0-fold (0.01 log units) below it, within the range that was stated.
By their numbers in this assay, from the lowest: compounds 1, 3 and 2 (each within the scatter of the next).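

With (2,6-difluorophenyl)carbamoyl in place of nonyl, a group with an aromatic ring, a hydrogen-bond donor and a hydrogen-bond acceptor enters this position, yet this assay shows no change beyond the scatter (a 1.1-fold higher number from compound 1 to compound 3 (0.04 log units; within the scatter)). The same holds against the aryl group (a 1.1-fold lower number from compound 2 to compound 3 (0.03 log units; within the scatter)), so three quite different groups on this aromatic nitrogen now give values within the scatter of one another. No measurement offers an explanation for this.

From the compounds shown here alone, whether a primary amine or a carboxylic acid at the end of the chain would shift the number remains open. So does the effect of a much shorter chain such as methyl.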